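A few compounds are considered here, and "the series" means these few. Any claim that something is new, unique, unknown or untested is made for them only; others in the source may bear on it.

Measured compounds:
- compound 1, `COc1cc(/C=N/Nc2nc(-c3ccccc3)cs2)c(Br)c(Br)c1OC`, 33600 nM
- compound 2, `Fc1ccc(/C=N/Nc2nc(-c3ccc(Br)cc3)cs2)cc1F`, > 100000 nM

Among the measured compounds shown here, only two compounds have been tested in a functional assay on HepG2 cells (Homo sapiens) for inhibition, read by MTT assay, with a stated time of 48 h (on this read-out higher numbers stand for weaker inhibition and lower numbers for stronger inhibition), and they share a core built around a hydrazone linked to a thiazole. In this assay, for the measured compounds named here, compound 1 gives 33600 nM, which is the only plain number among the results. One further result is a limit. For compound 2 the assay gives > 100000 nM, and that is a limit of the assay rather than a number. Going by the values given here, no two measured compounds differ in only one place, so there is no single measured step to lean on, and the limit of > 100000 nM in this assay, at which 1 of the 2 values shown sits, is the one piece of evidence beyond the values themselves.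

The untested compound 3, `COc1cc(/C=N/Nc2nc(-c3ccc(Br)cc3)cs2)c(Br)c(Br)c1OC`, is compound 1 with one change: bromo in place of hydrogen on an aromatic carbon. Seen one bond further out, the phenyl on the thiazole becomes a 4-bromophenyl. Among the compounds with values here, with no measured step of this kind at hand, the step from compound 1 to compound 3 is expected to be small, roughly within the scatter or slightly toward weaker inhibition, a 1.2-fold higher number from compound 1 to compound 3 (0.08 log units; within the scatter). Compound 3 is therefore estimated at 40000 nM, between 15000 nM and 100000 nM.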

Compound 3, half-maximal inhibitory concentration: > 100000 nM
Compound 3: no number, only a limit; the forecaster's own chance of this, stated with the estimate: 30%; at least 2.5-fold (0.39 log units) between middle value and limit.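

In this assay, the change from phenyl to 4-bromophenyl, on an aromatic carbon para to a large group, gives an at least 2.9-fold higher number from compound 1 to compound 3 (0.47 log units; beyond the scatter). Among the compounds shown here, this is the first single change whose direction can be read, and it shows that this position is not indifferent to what sits on it, since the step lies beyond the scatter and toward weaker inhibition. Compound 3 gives > 100000 nM, which is a limit of the assay and not a number, so the step has a floor but no ceiling, and its full size stays hidden at the top of the range: the limit of > 100000 nM in this assay, at which 2 of the 3 values shown sit.

Whether the same shift would follow from any group at this position, or is particular to bromo, stays open, as the compounds shown carry nothing else there, such as an amine or a carboxylic acid. This single pair also cannot tell whether bromo would have the same effect when the other aromatic ring carries different groups from those in compound 1.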